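The source may hold more compounds than are shown below. What is called first, only, known or untested is meant among the compounds shown, and "the series" means these compounds.

Measured so far:
compound 2 `COc1ccc(-c2ccc(-c3ccc(C(=N)N)o3)o2)cc1` gives 590 nM
compound 1 `N=C(N)c1ccc(-c2ccc(-c3cc(Cl)cc(Cl)c3)s2)s1` gives 1750 nM

Both numbers come from a functional assay on KM12 cells (Homo sapiens) for inhibition, read by sulforhodamine B assay, with a stated time of 48 h; on this read-out higher numbers stand for weaker inhibition of growth and lower numbers for stronger inhibition of growth. Going by the values given here, compound 2 stands at the lower of the two numbers, and the only other compound, compound 1, sits at a higher number, a gap that lies beyond the usual scatter of this assay. The two compounds share no single-point difference, so their gap cannot be read as one step.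

Compound 3 `N=C(N)c1ccc(-c2ccc(-c3ccc(Cl)cc3)o2)o1` has not been measured. It differs from compound 2 in one place, (chloro in place of methoxy on an aromatic carbon), on an aromatic carbon of a six-membered aromatic ring of carbon only, para to a large group. Among the compounds with values here, with no measured step of this kind to draw on, the change is expected to move the number only a little, if at all, beyond the scatter, estimated as a 1.4-fold higher number from compound 2 to compound 3 (0.13 log units; within the scatter) in this assay. Compound 3 is therefore expected to give about 800 nM, with a range from 300 nM to 2500 nM.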

Compound 3, concentration for 50% growth inhibition: 1630 nM
Estimate against measurement, compound 3: 2.0-fold (0.31 log units) below; measured number inside the range.
By their numbers in this assay, from the lowest: compound 2; then compounds 3 and 1 (each within the scatter of the next).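

Chloro in place of methoxy, on an aromatic carbon para to a large group, gives a 2.8-fold higher number from compound 2 to compound 3 (0.44 log units; beyond the scatter) in this assay and this is the first step here that can be read as a single change. Since a higher number stands for weaker inhibition of growth, this position is not indifferent to the group it carries, and methoxy does better there than chloro. Nothing at hand explains the size or direction of this step.

On these data alone, with only these two groups compared at this position, it remains open how a hydroxyl, an amine or a longer chain such as ethoxy would behave there. Also open, as far as these compounds go, is whether the same change would give a similar step on the core of compound 1.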